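Swapping pyrrolidin-1-yl for piperidin-1-yl in a cytotoxicity series

The source may hold more compounds than are shown below. What is called first, only, known or untested is meant among the compounds shown, and "the series" means these compounds.

Measured in an ADME assay on L6 cells (Rattus norvegicus) for cytotoxicity, read by resazurin assay, with a stated time of 72 h; a higher number here means a weaker inhibitor, a lower number a stronger inhibitor:
- compound 1 `NCCN1CCC2(N3CCCC3)CC(c3ccc(Cl)cc3)C1C(c1ccc(Cl)cc1)C2` gives 4650 nM
- compound 2 `NC(=O)CN1CCC2(N3CCCC3)CC(c3ccc(Cl)cc3)C1C(c1ccc(Cl)cc1)C2` gives 23900 nM
- compound 3 `CN(C)C12CCNC(C(c3cccc4ccccc34)C1)C(c1cccc3ccccc13)C2` gives 6470 nM

Compound 2 has the highest number of the three, so it takes the most material to reach the half-maximal effect on these cells. Its value of 23900 nM stands above those of both other compounds, by more than the usual scatter.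

The next compound is compound 4 `NC(=O)CN1CCC2(N3CCCCC3)CC(c3ccc(Cl)cc3)C1C(c1ccc(Cl)cc1)C2`, which keeps everything in compound 2 except one group: piperidin-1-yl in place of pyrrolidin-1-yl on a saturated ring carbon. Piperidin-1-yl takes the place of pyrrolidin-1-yl on a saturated ring carbon.

Among the compounds with values here, only one measured step is available, a 5.1-fold higher number from compound 1 to compound 2 (0.71 log units; beyond the scatter). It puts carbamoyl in place of aminomethyl on a saturated chain carbon bound to an amine nitrogen in a ring, so it is a modest step at a different place. Compound 3 differs from compound 2 in several places at once. Within the data shown here, no measured pair tests the ring swap itself, so no direction can be argued from the data, and the starting point remains the value of compound 2, 23900 nM.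

The estimated change in this assay is a 1.2-fold lower number from compound 2 to compound 4 (0.08 log units; within the scatter), which is expected to stay within the scatter. For compound 4 the expected value is 20000 nM, with an estimated range from 9000 nM to 45000 nM.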

Compound 4, half-maximal inhibitory concentration: 23800 nM
Compound 4: the middle estimate sits 1.2-fold (0.08 log units) below what was measured; measured number inside the range.
By their numbers in this assay, from the lowest: compounds 1 and 3 (each within the scatter of the next); then compounds 4 and 2 (each within the scatter of the next).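

In this assay, piperidin-1-yl in place of pyrrolidin-1-yl on this saturated ring carbon gives a 1.0-fold lower number from compound 2 to compound 4 (0.00 log units; within the scatter), so with carbamoyl kept on the chain, the six-membered non-aromatic ring and the five-membered one cannot be told apart here. Within the data shown here, this pair is the first direct test of this position, and it sets the swap apart from the only earlier step, a 5.1-fold higher number from compound 1 to compound 2 (0.71 log units; beyond the scatter), which was made at a different place and lies beyond the scatter. Among the compounds shown, then, the change on the chain shifts the number and the ring swap does not, although each change rests on a single pair, and no measured evidence is available to explain either result.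

The compounds shown leave open whether a larger ring such as azepan-1-yl, or a ring holding an oxygen atom such as morpholin-4-yl, would also stay within the scatter at this position. On these data alone, it is also open whether piperidin-1-yl would give the same result with aminomethyl on the chain, as in compound 1, instead of carbamoyl.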